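This account rests on a few compounds, and the source may have more. Where it says the series, first, only, none or still open, it means among the compounds named here.

In a functional assay on HT-29 cells (Homo sapiens) for antiproliferative activity, read by MTT assay, with a stated time of 72 h (a higher number here means a weaker inhibitor, a lower number a stronger inhibitor), compound 1 `CNc1nc(-c2cc(OC)c(OC)c(OC)c2)c(-c2ccc(OC)cc2)s1` stands at 6.3 nM and compound 2 `COc1ccc(-c2sc(N(C)C)nc2-c2cc(OC)c(OC)c(OC)c2)cc1` at 497 nM while compound 3 `COc1cc(-c2nc(C)sc2-c2ccc(C(F)(F)F)cc2)cc(OC)c1OC` stands at 396 nM within the scatter of compound 2 and far above compound 1. For the measured compounds named here, compound 4 `COc1ccc(-c2sc(C)nc2-c2cc(OC)c(OC)c(OC)c2)cc1` has methoxy in place of trifluoromethyl on an aromatic carbon and no measured step covers this change. Going by the values given here, the one measured step of a 79-fold higher number from compound 1 to compound 2 (1.90 log units; beyond the scatter) is large but lies on a nitrogen elsewhere, so it shows only how far the series can move. Compound 1 at 6.3 nM and compound 2 at 497 nM both carry that methoxy, so a moderate step to a lower number is expected in this assay with wide uncertainty. The expected move is a 6.6-fold lower number from compound 3 to compound 4 (0.82 log units; beyond the scatter) on this estimate. For compound 4 the estimate is 60 nM with an expected range from 8 nM to 400 nM in this assay.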

Compound 4, half-maximal inhibitory concentration: 1420 nM
Beside the measured number, compound 4's estimate is 24-fold (1.37 log units) below it; measured number above the stated range.
By their numbers in this assay, from the lowest: compound 1; then compounds 3 and 2 (each within the scatter of the next); then compound 4.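

In this assay, with methyl on the shared core, methoxy on the aromatic carbon para to a large group reads weaker than trifluoromethyl (a 3.6-fold higher number from compound 3 to compound 4 (0.55 log units; beyond the scatter)), so this change does not favour methoxy here. With methoxy held, the core substituent sets most of the range: methyl in place of dimethylamino is a modest loss (a 2.9-fold higher number from compound 2 to compound 4 (0.46 log units; beyond the scatter)), while methyl in place of methylamino is a large one (a 230-fold higher number from compound 1 to compound 4 (2.35 log units; beyond the scatter)). Nothing available accounts for either trend.

On these data alone, whether methoxy and trifluoromethyl keep this order with methylamino on the core stays open. So does how chloro, hydroxyl or ethoxy would read at this position.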